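Para-trifluoromethyl analogue of the aryl-alkyne series

The source may report more compounds than this note shows. Statements on the series, on what has been measured and on what is new or still open speak of the compounds shown alone.

Measured so far in a functional assay on K562 cells (Homo sapiens) for cytotoxicity; on this read-out lower numbers stand for stronger inhibition of growth and higher numbers for weaker inhibition of growth:
compound 1 `OCCCCC#Cc1ccccc1C#Cc1ccccc1`, 21100 nM
compound 2 `OCCCCC#Cc1ccccc1C#Cc1ccccn1`, 29000 nM
compound 3 `COc1cccc(C#Cc2ccccc2C#CCCCCO)c1`, 1800 nM

Compound 1 stands second highest of the three numbers; compound 2 lies closest, a 1.4-fold higher number from compound 1 to compound 2 (0.14 log units; within the scatter), while compound 3 lies furthest, a 12-fold lower number from compound 1 to compound 3 (1.07 log units; beyond the scatter). Compound 4 `OCCCCC#Cc1ccccc1C#Cc1ccc(C(F)(F)F)cc1` differs from compound 1 by trifluoromethyl in place of hydrogen on an aromatic carbon. Going by the values given here, no measured step covers this change. The step from compound 1 to compound 2 , a change on the same ring, stayed within the scatter; the step from compound 1 to compound 3 , a substituent added to that ring, was large. A substituent on the ring has so far gone one way only, in compound 3 alone, so a modest lowering is expected, a 1.8-fold lower number from compound 1 to compound 4 (0.25 log units; within the scatter), in this assay . Compound 4 is therefore estimated at 12000 nM, with a range from 3000 nM to 45000 nM.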

Compound 4, concentration for 50% growth inhibition: 18200 nM
For compound 4 the middle estimate is 1.5-fold (0.18 log units) below the measured one, within the range that was stated.
By their numbers in this assay, from the lowest: compound 3; then compounds 4, 1 and 2 (each within the scatter of the next).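

In this assay, trifluoromethyl para to a large group gives a 1.2-fold lower number from compound 1 to compound 4 (0.06 log units; within the scatter), so a substituent at this place does not by itself bring a large step like that of methoxy in a 12-fold lower number from compound 1 to compound 3 (1.07 log units; beyond the scatter). Among the substituted rings shown, only compound 3 moves beyond the scatter from compound 1. No measured evidence bears on why the two substituents differ.

Still open, going by these compounds, is whether methoxy para to a large group would keep the large step, and how an amine or a carboxylic acid would read at that place.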